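The compounds below may be only part of what the source reports. "The series", "measured", "known", "first", "only" and "open" are said of these compounds alone.

Compound 1 `C=C1C[C@]23C[C@@]1(O)CC[C@@H]2c1cccc(C)c1[C@@H]3Cn1cc(-c2ccc(Cl)cc2)nn1`: > 20000 nM
Compound 2 `C=C1C[C@]23C[C@@]1(O)CC[C@@H]2c1cccc(C)c1[C@@H]3Cn1cc(-c2ccc(Br)cc2)nn1`: > 20000 nM

In a functional assay on SMMC-7721 cells (Homo sapiens) for cytotoxicity, read by MTT assay, with a stated time of 4 days (a higher number here means a weaker inhibitor, a lower number a stronger inhibitor), compound 1 gives > 20000 nM, which is a limit of the assay rather than a number. Compound 2 gives > 20000 nM in this assay, again a limit. Going by the values given here, the only measured step, a step that the two limits leave unreadable from compound 1 to compound 2, is thus unreadable in size; both values sit at the limit of > 20000 nM in this assay, at which 2 of the 2 values shown sit. Compound 3 `C=C1C[C@]23C[C@@]1(O)CC[C@@H]2c1cccc(C)c1[C@@H]3Cn1cc(-c2ccccn2)nn1` is not yet measured and differs from compound 2 by pyridin-2-yl in place of 4-bromophenyl on an aromatic carbon. Among the compounds with values here, no measured step shows how this change acts, so compound 3 is expected to remain at the limit. Compound 3 is estimated at 25000 nM (range 8000 nM to 80000 nM). The expected step is a step that the limit leaves unreadable from compound 2 to compound 3, none beyond the scatter.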

Compound 3, half-maximal inhibitory concentration: > 20000 nM
Compound 3: only a limit was reported; the forecaster's own chance of this, stated with the estimate: 85%; the middle value does not contradict the limit.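

Compound 3 gives > 20000 nM in this assay, which is again a limit of the assay, so its steps from compound 1 and compound 2 cannot be read. The compounds shown leave open how pyridin-2-yl, 4-bromophenyl and 4-chlorophenyl truly compare in this assay.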